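The source may hold more compounds than are shown below. What is called first, only, known or untested is meant among the compounds shown, and "the series" means these compounds.

Measured compounds:
Compound 1 `CS(=O)(=O)c1ccc(C(=O)N2CCC(C(=O)N(Cc3ccccc3)c3ccccc3)CC2)cc1[N+](=O)[O-]`. In an ADME assay on HepG2 cells (Homo sapiens) for cytotoxicity, read by CellTiter-Glo and ATP content, with a stated time of 72 h (a lower number here means that less compound is needed, a higher number that more compound is needed for the effect), compound 1 gives > 27000 nM, a limit of the assay rather than a number.
Compound 2 `CN(Cc1ccccc1)C(=O)C1CCN(C(=O)c2ccc(S(C)(=O)=O)c([N+](=O)[O-])c2)CC1`. In this assay compound 2 gives > 27000 nM, again a limit of the assay.
Compound 3 `CC(C)N(C(=O)CNC(=O)c1ccc(S(C)(=O)=O)c([N+](=O)[O-])c1)C(C)C`. In this assay compound 3 gives > 27000 nM, also a limit of the assay.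

Compound 2 therefore stands at the limit of this assay, as do the two other measured compounds, which is the whole of the evidence here: the limit of > 27000 nM in this assay, at which 3 of the 3 values shown sit.

The unmeasured compound 4 `CC(C)N(C(=O)C1CCN(C(=O)c2ccc(S(C)(=O)=O)c([N+](=O)[O-])c2)CC1)C(C)C` differs from compound 2 in one place: diisopropylamino in place of benzyl(methyl)amino on a carbonyl carbon. For the measured compounds named here, the only measured step touching this region is the change of a step that the two limits leave unreadable from compound 1 to compound 2, whose size cannot be read because both ends sit at the limit. Going by the values given here, no measured step therefore gives a readable size for the move from compound 2 to compound 4, and compound 3, which already carries the diisopropylamino group, also sits at the limit.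

With all three measured values at the limit, compound 4 is expected to remain at that limit in this assay, most likely reported as a limit rather than a number. Compound 4 is estimated at 40000 nM, with a range from 20000 nM to 100000 nM. The expected step is a step that the limit leaves unreadable from compound 2 to compound 4, none beyond the scatter.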

Compound 4, half-maximal effective concentration: > 27000 nM
Compound 4: a limit, no number; the forecaster's own chance of this, stated with the estimate: 85%; the middle value does not contradict the limit.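

In this assay, for the compounds shown here, compound 4 gives > 27000 nM, a limit of the assay and not a number; compound 2 also sits at a limit, so no step between compound 2 and compound 4 can be read. The compounds shown leave open what effective concentration any of them has, and whether any change to them would shift it: the limit of > 27000 nM in this assay, at which 4 of the 4 values shown sit.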